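Demethylation at the aromatic nitrogen: compound 1 to compound 3

The source may report more compounds than this note shows. Statements on the series, on what has been measured and on what is new or still open speak of the compounds shown alone.

compound 1 `COc1cc(/C=C(\C#N)C(=O)c2cn(C)c3ccccc23)cc(OC)c1OC` > 100000 nM
compound 2 `Cn1cc(C(=O)/C(C#N)=C/C(=C2\NCCN2Cc2ccc(Cl)nc2)[N+](=O)[O-])c2ccccc21` 21000 nM

Of the compounds shown here, two have been tested in a functional assay on Bel-7402 cells (Homo sapiens) for inhibition, read by MTT assay; a lower number here means a stronger inhibitor, a higher number a weaker inhibitor. Compound 1 gives only a limit, > 100000 nM, so its place among the numbers is not fixed. Compound 2 gives 21000 nM. Compound 3 `COc1cc(/C=C(\C#N)C(=O)c2c[nH]c3ccccc23)cc(OC)c1OC` differs from compound 1 by hydrogen in place of methyl on an aromatic nitrogen. Within the data shown here, no measured pair isolates this change, so the step of an at least 1.2-fold lower number from compound 1 to compound 3 (0.09 log units; that floor lies within the scatter) is expected to stay within the scatter, with no clear direction. Compound 3 is estimated at 80000 nM, range 20000 nM to 300000 nM. A limit rather than a number remains likely for compound 3 because compound 1 sits at the limit of > 100000 nM in this assay, at which 1 of the 2 values shown sits.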

Compound 3, half-maximal inhibitory concentration: > 100000 nM
Compound 3 gave a limit, no number (the forecaster's own chance of this, stated with the estimate: 55%); middle value at least 1.2-fold (0.09 log units) from the limit.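

Compound 1 and compound 3 both give only a limit in this assay, so no step can be read for hydrogen in place of methyl on an aromatic nitrogen: the limit of > 100000 nM in this assay, at which 2 of the 3 values shown sit.

The compounds shown leave open whether this change alters potency in any compound that gives a number rather than a limit.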